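Swapping fluoro for methyl on a bound acid

The source may report more compounds than this note shows. Statements on the series, on what has been measured and on what is new or still open speak of the compounds shown alone.

Measured so far in an ADME assay on a cell-free system (plasma, Rattus norvegicus) (a higher number here means a larger unbound share of the compound, a lower number a smaller unbound share), are two compounds.
- compound 1 `Cc1ccc(S(=O)(=O)NC(C)C)cc1C#Cc1cc(Cl)ccc1OCC(=O)O` gives 0.004 as its value
- compound 2 `CS(=O)(=O)c1ccc(F)c(C#Cc2cc(Cl)ccc2OCC(=O)O)c1` gives 0.011 as its value

Of these two, compound 2 stands higher, and the gap down to compound 1 lies beyond the scatter. Both numbers are small, so only a minor share of either compound is unbound.

The next compound to be measured is compound 3 `Cc1ccc(S(C)(=O)=O)cc1C#Cc1cc(Cl)ccc1OCC(=O)O` which has methyl in place of fluoro on an aromatic carbon of compound 2 methyl in place of fluoro on an aromatic carbon and keeps everything else. Within the data shown here, no measured pair isolates this change, so any forecast rests on thin ground. Compound 1 also carries a methyl and gives 0.004 as its value, which points weakly downward, though a single compound sets no rule. The expected change is a modest fall, and the estimated step of a 1.6-fold lower number from compound 2 to compound 3 (0.20 log units; within the scatter) stays close to the scatter. In this assay compound 3 is expected at 0.007 with 0.003 to 0.015 as the estimated range.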

Compound 3, unbound fraction: 0.014
Beside the measured number, compound 3's estimate is 2.0-fold (0.30 log units) below it; the range from low to high includes it.
By their numbers in this assay, from the lowest: compound 1; then compounds 2 and 3 (each within the scatter of the next).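

In this assay methyl and fluoro on this aromatic carbon, ortho to a large group and para to a methylsulfonyl group, are not told apart: the swap gives a 1.3-fold higher number from compound 2 to compound 3 (0.10 log units; within the scatter) and so leaves the unbound fraction within the usual scatter. Compound 3 also supplies a single-place comparison on the sulfonyl sulfur, which compound 1 and compound 2 could not offer, and methyl in place of isopropylamino gives a 3.5-fold higher number from compound 1 to compound 3 (0.54 log units; beyond the scatter) even though the aromatic methyl is present in both compounds, so in this pair the lower number of compound 1 goes with the isopropylamino group and not with that methyl. Nothing measured here offers an explanation for either step.

Two small atoms at one position say little about how the unbound fraction would respond to a larger or differently built group there, such as a methoxy group or an amine. Going by these compounds, on the sulfonyl sulfur only methyl and isopropylamino can be compared, so it remains open where an ethyl group or a morpholine ring would fall.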